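Series notes: cytotoxicity of 2-substituted nicotinonitrile analogues

This account rests on a few compounds, and the source may have more. Where it says the series, first, only, none or still open, it means among the compounds named here.

Measured so far:
compound 1, `CC(C)c1ccc(-c2cc(-c3ccc4c(c3)CCCC4)nc(Cl)c2C#N)cc1`, 8400 nM
compound 2, `COc1ccc(-c2cc(-c3ccc4c(c3)CCCC4)nc(NCc3ccccc3)c2C#N)cc1OC`, 4900 nM

Both measured compounds share the same core and were tested in an ADME assay on RAW264.7 cells (Mus musculus) for cytotoxicity, with a stated time of 24 h; a higher number here means a weaker inhibitor, a lower number a stronger inhibitor. Compound 1 gives 8400 nM and compound 2 gives 4900 nM. Compound 2 stands at the low end of the two numbers, but the gap to compound 1 lies within the usual scatter, so the two cannot be separated on these data. Going by the values given here, compound 1 and compound 2 differ in two places at once, so no single step between measured compounds is available.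

Compound 3, `CC(C)c1ccc(-c2cc(-c3ccc4c(c3)CCCC4)nc(NCc3ccccc3)c2C#N)cc1`, is not yet measured. It differs from compound 2 in one place: 4-isopropylphenyl in place of 3,4-dimethoxyphenyl on an aromatic carbon. Compound 1 already carries this 4-isopropylphenyl group and sits within the scatter of compound 2, so no step beyond the scatter is expected here. The expected step of a 1.2-fold higher number from compound 2 to compound 3 (0.09 log units; within the scatter) should stay inside the scatter. Compound 3 is accordingly estimated at 6000 nM, with a range from 2500 nM to 15000 nM.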

Compound 3, half-maximal inhibitory concentration: > 50000 nM
Compound 3 gave a limit, no number (the forecaster's own chance of this, stated with the estimate: 10%); middle value at least 8.3-fold (0.92 log units) away from the limit.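

In this assay compound 3 stands as a limit and not as a number: the limit of > 50000 nM in this assay, at which 1 of the 3 values shown sits. On the aromatic carbon opposite the ring nitrogen, with benzylamino held in place, 4-isopropylphenyl in place of 3,4-dimethoxyphenyl gives an at least 10-fold higher number from compound 2 to compound 3 (1.00 log units; beyond the scatter) and so separates two compounds differing in one place, which compound 1 and compound 2, differing in two places and lying within the scatter, could not do. With 4-isopropylphenyl held in place, benzylamino in place of chloro gives an at least 5.9-fold higher number from compound 1 to compound 3 (0.77 log units; beyond the scatter), so the result at this aryl position depends on what else the core carries or the two changes each act alone, and these compounds do not separate those readings.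

As far as these compounds go, the full size of both steps stays open at this limit. Also open is which part of the 3,4-dimethoxyphenyl group matters, as a phenyl with a single methoxy or a hydroxy group lies outside the compounds shown.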